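The source may report more compounds than this note shows. Statements on the series, on what has been measured and on what is new or still open speak of the compounds shown alone.

Two compounds of this series have been taken to an ADME assay on a cell-free system (plasma, Rattus norvegicus) (a higher number here means a larger unbound share of the compound, a lower number a smaller unbound share), and only one of them gave a number. Compound 1 `CC(C)S(=O)(=O)c1ccc(Cl)c(C#Cc2cc(Cl)ccc2OCC(=O)O)c1` has no result, its entry reading "not determined" (no result reported), so it offers no guidance here. Compound 2 `CC(C)c1ccc(S(C)(=O)=O)cc1C#Cc1cc(Cl)ccc1OCC(=O)O` gives 0.004, which is a very small unbound share and the only figure available in this assay. With a single number, nothing can yet be said about how compound 2 ranks within the series.

The next compound, compound 3 `CS(=O)(=O)c1ccc(Cl)c(C#Cc2cc(Cl)ccc2OCC(=O)O)c1`, keeps the shared core but carries chloro in place of isopropyl on an aromatic carbon. This carbon is ortho to a large group and para to a methylsulfonyl group. Within the data shown here, no pair of measured compounds shows what a change like this does, so the expectation is a cautious judgement from the structural change alone. The expected 2.0-fold higher number from compound 2 to compound 3 (0.30 log units; within the scatter) is a small rise, at about the edge of the usual scatter. For compound 3, the estimated unbound fraction is 0.008, with an expected range from 0.003 to 0.02.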

Compound 3, unbound fraction: 0.003
Estimate against measurement, compound 3: 2.7-fold (0.43 log units) above, and the stated range covers the measured number.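

In this assay the position on an aromatic carbon, ortho to a large group and para to a methylsulfonyl group, now has its first readable step: chloro in place of isopropyl gives a 1.3-fold lower number from compound 2 to compound 3 (0.12 log units; within the scatter) and this places the two compounds within the normal spread of repeat measurements, so they cannot be told apart. Exchanging a group of 3 heavy atoms for one of 1 heavy atom therefore has no detectable effect on the unbound share in this pair, and both compounds remain at very small values. Nothing shown here gives a measured explanation for this result.

The comparison covers only isopropyl and chloro at this one position, so it cannot show whether an amine, a hydroxyl group or a longer chain there would give a clearly different unbound share. It also leaves open whether the same exchange would behave alike on a different core or with a different group on the sulfonyl, since one pair cannot establish a general pattern.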